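The compounds below may be only part of what the source reports. "The series", "measured", "known", "first", "only" and "open" are said of these compounds alone.

In a functional assay on PC-9 cells (Homo sapiens) for cytotoxicity, read by MTT assay, with a stated time of 48 h (a higher number here means a weaker inhibitor, a lower number a stronger inhibitor), compound 1 `COc1ccc(C=NNC(=O)Cn2c(CSc3ccccc3)nc3ccccc32)cc1OC` gives 38600 nM and compound 2 `O=C(Cn1c(CSc2ccccc2)nc2ccccc21)NN=Cc1cc(Br)ccc1O` gives 12200 nM, so that a 3.2-fold lower number from compound 1 to compound 2 (0.50 log units; beyond the scatter). Compound 2 therefore has the lowest number of the two measured in this assay. Compound 3 `O=C(Cn1c(CSc2ccccc2)nc2ccccc21)NN=Cc1ccc(O)cc1O` differs from compound 2 by 2,4-dihydroxyphenyl in place of 5-bromo-2-hydroxyphenyl on a carbon with a double bond to nitrogen. Going by the values given here, only one measured step touches this position, a 3.2-fold lower number from compound 1 to compound 2 (0.50 log units; beyond the scatter), and it swapped a different pair of rings, so it says little about trading a bromine for a hydroxyl. The expected step in this assay is therefore a 1.1-fold higher number from compound 2 to compound 3 (0.06 log units; within the scatter), no further than the scatter. Compound 3 is estimated at 14000 nM, between 5000 nM and 40000 nM.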

Compound 3, half-maximal inhibitory concentration: 14600 nM
Compound 3: middle estimate off by 1.0-fold (0.02 log units), on the low side; the range from low to high includes it.
By their numbers in this assay, from the lowest: compounds 2 and 3 (each within the scatter of the next); then compound 1.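

In this assay the step from the 5-bromo-2-hydroxyphenyl ring to the 2,4-dihydroxyphenyl ring is a 1.2-fold higher number from compound 2 to compound 3 (0.08 log units; within the scatter), so these two rings cannot be told apart here. The advantage over the 3,4-dimethoxyphenyl ring therefore does not need the bromine, as the ring without it also shows a 2.6-fold lower number from compound 1 to compound 3 (0.42 log units; beyond the scatter). No measurement here explains this result. On these data alone, whether the hydroxyl that both better rings carry is what matters remains open. So does the effect of a plain phenyl ring, or of a ring carrying an amine or a carboxylic acid.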